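The source may hold more compounds than are shown below. What is called first, only, known or untested is meant among the compounds shown, and "the series" means these compounds.

Three amides built on the same core have been measured in an assay on LtK cells with ATP-sensitive inward rectifier potassium channel 11 (Homo sapiens) as the target; on this read-out higher numbers stand for an effect only at larger amounts of compound and lower numbers for an effect already at smaller amounts. Compound 1, `CCC(CC)C(=O)Nc1c(C(O)(C(F)(F)F)C(F)(F)F)ccc2ccccc12`, carries a pentan-3-yl group on the carbonyl carbon and gives 4340 nM. Compound 2, `O=C(Nc1c(C(O)(C(F)(F)F)C(F)(F)F)ccc2ccccc12)C1CC1`, gives 751 nM. Compound 3, `O=C(CCc1ccccc1)Nc1c(C(O)(C(F)(F)F)C(F)(F)F)ccc2ccccc12`, gives 1750 nM, which places it second highest of the three, between the other two: a 2.5-fold lower number from compound 1 to compound 3 (0.39 log units; beyond the scatter), while a 2.3-fold higher number from compound 2 to compound 3 (0.37 log units; beyond the scatter). All three steps between the measured compounds change only the group on the carbonyl carbon, and none exceeds a modest size, for example a 5.8-fold lower number from compound 1 to compound 2 (0.76 log units; beyond the scatter).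

Compound 4, `O=C(NCCCCCCCl)Nc1c(C(O)(C(F)(F)F)C(F)(F)F)ccc2ccccc12`, differs from compound 3 in the same place: (6-chlorohexyl)amino in place of phenethyl on a carbonyl carbon. Within the data shown here, this turns the amide into a urea bearing a chain, a change no measured pair covers, so the expectation rests only on the modest spread seen so far. A modest shift in either direction is expected in this assay, with no clear favoured direction, so the estimated step is a 1.4-fold higher number from compound 3 to compound 4 (0.15 log units; within the scatter). Compound 4 is expected to give about 2500 nM, within a range from 700 nM to 9000 nM.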

Compound 4, half-maximal effective concentration: 4840 nM
Compound 4: middle estimate off by 1.9-fold (0.29 log units), on the low side; the measured number falls inside the stated range.
By their numbers in this assay, from the lowest: compound 2; then compound 3; then compounds 1 and 4 (each within the scatter of the next).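

In this assay, replacing phenethyl with (6-chlorohexyl)amino on the carbonyl carbon turns the amide into a urea, loses the aromatic ring and adds a hydrogen-bond donor, and the number rises (a 2.8-fold higher number from compound 3 to compound 4 (0.44 log units; beyond the scatter)), while the gap to the cyclopropyl amide widens (a 6.4-fold higher number from compound 2 to compound 4 (0.81 log units; beyond the scatter)). Compound 4 also stands level with the pentan-3-yl amide, since that step lies within the scatter (a 1.1-fold higher number from compound 1 to compound 4 (0.05 log units; within the scatter)), so compound 2 keeps the lowest number of the four. The data give no measured explanation for these steps.

As far as these compounds go, because the urea link and the chain change together, their separate contributions remain open. A urea carrying cyclopropyl, or an amide carrying a hexyl chain with or without the terminal chlorine, would pull those contributions apart.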